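The source may hold more compounds than are shown below. What is called first, only, known or untested is meant among the compounds shown, and "the series" means these compounds.

Measured compounds:
Compound 1, `O=C(Nc1ccccc1C(F)(F)F)C1CCc2ccccc2N1C(=O)c1ccccc1`, gives 6500 nM in a functional assay on HCT-15 cells (Homo sapiens) for cytotoxicity, read by sulforhodamine B assay, with a stated time of 72 h; on this read-out lower numbers stand for stronger inhibition of growth and higher numbers for weaker inhibition of growth.
Compound 2, `COc1ccc(NC(=O)C2CCc3ccccc3N2)cc1`, gives 50200 nM in this assay.
Compound 3, `O=C(Nc1cc(C(F)(F)F)cc(C(F)(F)F)c1)C1CCc2ccccc2N1C(=O)c1ccc(Cl)cc1`, gives 2220 nM in this assay.

Among these three numbers compound 3 stands lowest in this assay. Compound 1 is nearest to it, with a higher number that lies beyond the scatter, and compound 2 is furthest, with a much higher number, also beyond the scatter. Among the compounds with values here, no two of the measured compounds differ in only one place, so no single step is known here.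

Compound 4, `O=C(Nc1cc(C(F)(F)F)cc(C(F)(F)F)c1)C1CCc2ccccc2N1C(=O)c1cccc(Cl)c1`, is not yet measured in this assay. It differs from compound 3 by 3-chlorophenyl in place of 4-chlorophenyl on a carbonyl carbon, the two having the same atoms joined differently. Within the data shown here, no measured pair shows what moving the chlorine on this phenyl does, so the expectation rests on compound 3 alone. Compound 4 is expected to give about 2500 nM, in a range from 800 nM to 8000 nM. The step this estimate means, a 1.1-fold higher number from compound 3 to compound 4 (0.05 log units; within the scatter), is expected to stay within the scatter, in no particular direction.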

Compound 4, concentration for 50% growth inhibition: 625 nM
Beside the measured number, compound 4's estimate is 4.0-fold (0.60 log units) above it; the measured number lies below the stated range.
By their numbers in this assay, from the lowest: compound 4; then compound 3; then compound 1; then compound 2.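

Within the data shown here, this is the first single change that can be read. With the same atoms joined differently, 3-chlorophenyl in place of 4-chlorophenyl on a carbonyl carbon gives a 3.6-fold lower number from compound 3 to compound 4 (0.55 log units; beyond the scatter) in this assay, so where the chlorine sits on this phenyl affects growth inhibition in these cells, even with nothing else in the molecule altered. No measurement here gives a reason for this difference.

The compounds shown leave open how a fluorine, a methoxy group or a nitrile would read in place of the chlorine on this phenyl. Among these compounds, they also do not show whether moving the chlorine has a step of similar size when another part of the molecule is changed, since this is the only such pair.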